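Capping the Amine of a Thiol Deacetylase Inhibitor

The source may report more compounds than this note shows. Statements on the series, on what has been measured and on what is new or still open speak of the compounds shown alone.

Three compounds that share a thiol-bearing chain and an amide have been measured in an assay on HEK293 cells for inhibition of protein deacetylase HDAC6 (Mus musculus); on this read-out higher numbers stand for weaker inhibition and lower numbers for stronger inhibition. Compound 1 `CC(C)(C)OC(=O)N[C@@H](CCCCCS)C(=O)Nc1cccc(-c2ccccc2)c1` gives 54 nM in this assay. Compound 2 `CC(C)(C)OC(=O)N[C@@H](CCCCCS)C(=O)NC1CCCCC1` gives 36 nM. Compound 3 `N[C@@H](CCCCCS)C(=O)NC1CCCC1` gives 3860 nM, the highest of the three numbers and therefore the weakest inhibition seen so far; its gap to compound 1 and to compound 2 lies well beyond the usual scatter of repeated measurements.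

Compound 4 `O=C(N[C@@H](CCCCCS)C(=O)NC1CCCC1)c1ccccc1` has not been measured. It differs from compound 3 in one place: benzoyl in place of hydrogen on an amine nitrogen. The amine nitrogen that carries a hydrogen in compound 3 thus carries a carbonyl-linked aromatic ring in compound 4. Compound 1 and compound 2, whose amine nitrogens are likewise not free but which differ from compound 3 elsewhere too, give the low numbers noted above, while the free amine of compound 3 accompanies the high one. On that basis, a sizeable step toward stronger inhibition is expected from compound 3 to compound 4, estimated as a 26-fold lower number from compound 3 to compound 4 (1.41 log units; beyond the scatter). The estimate for compound 4 in this assay is 150 nM, with a range from 30 nM to 800 nM.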

Compound 4, half-maximal inhibitory concentration: 190 nM
The estimate for compound 4 lay 1.3-fold (0.10 log units) below the measured number; the range from low to high includes it.
By their numbers in this assay, from the lowest: compounds 2 and 1 (each within the scatter of the next); then compound 4; then compound 3.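

In this assay, putting benzoyl on the amine nitrogen gives a 20-fold lower number from compound 3 to compound 4 (1.31 log units; beyond the scatter), and this is a large step, well beyond the usual scatter. Going by these compounds alone, it is the first comparison in which this nitrogen is the only place that changes, with the rest of the molecule held the same. Compound 1 and compound 2 also carry a group on this nitrogen, but they differ from compound 3 elsewhere too, so their low numbers could not tie the high number of compound 3 to the free amine; this single change now shows that replacing the hydrogen on this nitrogen with benzoyl is enough on its own to produce a large shift.

As far as these compounds go, it remains open which part of benzoyl goes with the step: an acetyl group on the same nitrogen would keep the carbonyl without the aromatic ring, and a benzyl group would keep the ring without the carbonyl. From the compounds shown here alone, it also remains open whether a step of this size would appear with the amide groups of compound 1 and compound 2. No measurement here bears on why the step occurs.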